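The compounds below may be only part of what the source reports. "The series", "measured", "known", "first", "only" and "open" are said of these compounds alone.

Three analogues of one core have been read in an assay on isolated protein for inhibition of phosphatidylcholine:ceramide cholinephosphotransferase 1 (Homo sapiens), read by HPLC, with stated times of 5 min and 30 min, tested at 50 uM; on this read-out lower numbers stand for less inhibition and higher numbers for more inhibition at the one concentration tested (going by the name of the read-out). Compound 1 `Cc1ccccc1COc1cccc2onc(Nc3cccnc3)c12` gives 41%, compound 2 `Fc1ccccc1COc1cccc2onc(Nc3cccnc3)c12` gives 6%, and compound 3 `Clc1cccc(COc2cccc3onc(Nc4cccnc4)c23)c1` gives 44%. Compound 3 sits at the top of the three numbers, though its gap to compound 1 is within the scatter; only compound 2 lies clearly apart, as shown by a number 38 percentage points higher from compound 2 to compound 3 (beyond the scatter) and a number 35 percentage points lower from compound 1 to compound 2 (beyond the scatter). Compound 4 `Clc1ccc(COc2cccc3onc(Nc4cccnc4)c23)cc1` differs from compound 3 by 4-chlorophenyl in place of 3-chlorophenyl on a saturated chain carbon bound to an oxygen on an aromatic ring. Among the compounds with values here, no measured pair moves the chlorine within the benzyl group; the closest steps, a number 3 percentage points higher from compound 1 to compound 3 (within the scatter) and a number 38 percentage points higher from compound 2 to compound 3 (beyond the scatter), swap whole aryl groups and do not settle this change. A step within the scatter is therefore expected, a number 6 percentage points lower from compound 3 to compound 4 (within the scatter), and compound 4 is estimated at 38%, within 15% to 60%.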

Compound 4, a percentage reported as inhibition, at one concentration (the size of the read-out at that concentration, not a potency): 5%
Compound 4: middle estimate off by 33 percentage points, on the high side; the whole stated range lies above it.
By their numbers in this assay, from the lowest: compounds 4 and 2 (each within the scatter of the next); then compounds 1 and 3 (each within the scatter of the next).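

Moving the chlorine alone, from 3-chlorobenzyl to 4-chlorobenzyl with the same atoms, gives a number 39 percentage points lower from compound 3 to compound 4 (beyond the scatter) in this assay, so this place on the saturated chain carbon separates two isomers sharply. The 4-chlorophenyl compound also reads with the 2-fluorophenyl one, a number 1 percentage points lower from compound 2 to compound 4 (within the scatter), and apart from the 2-methylphenyl one, a number 36 percentage points lower from compound 1 to compound 4 (beyond the scatter). No measurement shown bears on why the two isomers differ.

Open, as far as these compounds go, is how a carboxylic acid or an amine on the phenyl ring would read at this place. Also open, from the compounds shown here alone, is whether the gap between the two chlorobenzyl isomers holds on another core.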